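The compounds below may be only part of what the source reports. "The series", "measured", "known", "first", "only" and "open" are said of these compounds alone.

Of the compounds shown here, two built on a shared core have been measured in a functional assay on HCT-116 cells (Homo sapiens) for inhibition, read by sulforhodamine B assay, with a stated time of 48 h; on this read-out lower numbers stand for stronger inhibition of growth and higher numbers for weaker inhibition of growth. Compound 1 `COc1cc(-c2nn(-c3cccc(NC(=O)Nc4cc(C(F)(F)F)cc(C(F)(F)F)c4)c3)cc2-c2ccncc2)ccc1Cl` gives 643 nM in this assay. Compound 2 `COc1cc(-c2nn(-c3cccc(NC(=O)c4cccc(C(F)(F)F)c4)c3)cc2-c2ccncc2)ccc1Cl` gives 1670 nM in this assay and so stands at the higher of the two numbers; its gap to compound 1 lies beyond the scatter of repeated measurements. A third compound, compound 3 `COc1cc(-c2nn(-c3cccc(NC(=O)Nc4ccc(Cl)c(Cl)c4)c3)cc2-c2ccncc2)ccc1Cl`, has not yet been measured. Compound 3 differs from compound 2 in one place: (3,4-dichlorophenyl)amino in place of 3-(trifluoromethyl)phenyl on a carbonyl carbon. Compound 1 shares with compound 3 an amino group on the carbonyl carbon, and compound 1 gives 643 nM in this assay, the lower of the two measured numbers. On that basis the step from compound 2 to compound 3 is expected to run toward lower numbers and to be larger than the scatter, with a size of roughly a 2.4-fold lower number from compound 2 to compound 3 (0.38 log units; beyond the scatter) expected. For compound 3 the estimate in this assay is 700 nM, with a range from 300 nM to 1600 nM.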

Compound 3, concentration for 50% growth inhibition: 1210 nM
For compound 3 the middle estimate is 1.7-fold (0.24 log units) below the measured one, within the range that was stated.
By their numbers in this assay, from the lowest: compounds 1, 3 and 2 (each within the scatter of the next, the first and the last beyond it).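

In this assay, putting (3,4-dichlorophenyl)amino in place of 3-(trifluoromethyl)phenyl on the carbonyl carbon gives a 1.4-fold lower number from compound 2 to compound 3 (0.14 log units; within the scatter), so the two numbers cannot be told apart even though the aromatic ring's substituents change and an amino group with its hydrogen-bond donor enters. This shows that, at this position, an amino group on the carbonyl carbon does not bring a step beyond the scatter when it arrives together with the 3,4-dichlorophenyl ring, so sharing that amino group with compound 1 was not enough to separate compound 3 from compound 2. Nothing available here bears on why this step is so small.

The compounds shown leave open how much of this step belongs to the amino group and how much to the change of ring substituents, since both change together. They also leave open how the series would read with a methylamino group or an ether oxygen in place of the amino group on the carbonyl carbon.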